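Chloro on the pyridin-3-yl ring: from compound 1 to compound 3

A few compounds are considered here, and "the series" means these few. Any claim that something is new, unique, unknown or untested is made for them only; others in the source may bear on it.

Compound 1 `C=CC(=O)Nc1cccc(Nc2ncnc(Nc3ccc(-c4cccnc4)cc3)n2)c1` is the starting point. In a functional assay on Ramos cells (Homo sapiens) for antiproliferative activity, read by CCK-8 assay, with a stated time of 24 h (a higher number here means a weaker inhibitor, a lower number a stronger inhibitor), compound 1 gives only a limit of > 100000 nM, not a measured number, and so it sits at the limit of > 100000 nM in this assay, at which 1 of the 2 values shown sits. Compound 2 `C=CC(=O)Nc1cccc(Nc2nc(N)nc(Nc3ccc(Oc4ccccc4)cc3)n2)c1` differs from compound 1 in several places. In this assay compound 2 gives 20000 nM. Compound 3 `C=CC(=O)Nc1cccc(Nc2ncnc(Nc3ccc(-c4ccc(Cl)nc4)cc3)n2)c1` differs from compound 1 in a single way: chloro in place of hydrogen on an aromatic carbon. Among the measured compounds shown here, no measured pair shows this change, so no step beyond the usual scatter is expected. Compound 3 is therefore expected to give about 100000 nM in this assay, within a range from 30000 nM to 300000 nM. The implied step, a number no higher from compound 1 to compound 3 (the limit leaves the size open), is expected to be essentially none.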

Compound 3, half-maximal inhibitory concentration: 160000 nM
Beside the measured number, compound 3's estimate is 1.6-fold (0.20 log units) below it, within the range that was stated.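

No step can be read from compound 1 to compound 3. Compound 1 has only a limit, not a measured number: the limit of > 100000 nM in this assay, at which 1 of the 3 values shown sits. The compounds shown leave open whether chloro in place of hydrogen shifts the value at all, and in which direction.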